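The source may hold more compounds than are shown below. What is called first, only, known or untested is meant among the compounds shown, and "the series" means these compounds.

Measured so far:
- Compound 1, `CC(C)N(C)c1ccc2cc(NC(=O)CCc3ccc(C(F)(F)F)cc3)ccc2n1`: 2 nM
- Compound 2, `CN(c1ccc2cc(NC(=O)CCc3ccc(C(F)(F)F)cc3)ccc2n1)C1CCCCC1`: 18 nM
- Compound 3, `CCCN(CCC)c1ccc2cc(NC(=O)CCc3ccc(C(F)(F)F)cc3)ccc2n1`: 490 nM

In an assay on isolated protein for displacement of a labelled ligand from melanin-concentrating hormone receptor 1 (Homo sapiens) (a higher number here means a weaker inhibitor, a lower number a stronger inhibitor), compound 3 gives the highest number of the three: the gap is a 27-fold higher number from compound 2 to compound 3 (1.43 log units; beyond the scatter) and, further still, a 250-fold higher number from compound 1 to compound 3 (2.39 log units; beyond the scatter). Compound 4, `O=C(CCc1ccc(C(F)(F)F)cc1)Nc1ccc2nc(N3CCCCCC3)ccc2c1`, differs from compound 3 in one place: azepan-1-yl in place of dipropylamino on an aromatic carbon. The two propyl chains are, in effect, tied into a single ring.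

Going by the values given here, no measured step closes a chain into a ring, so none bears on this change directly. What the measured steps do show is that the dipropylamino group sits well behind the two compact amines: a 250-fold higher number from compound 1 to compound 3 (2.39 log units; beyond the scatter) and a 27-fold higher number from compound 2 to compound 3 (1.43 log units; beyond the scatter). Compound 2, which carries a ring on its nitrogen, reaches 18 nM. Going from two open chains to a seven-membered ring of the same size seems likely to move the number in that direction, though not as far as compound 2. A step beyond the scatter, toward a lower number, is therefore expected: a 6.1-fold lower number from compound 3 to compound 4 (0.79 log units; beyond the scatter). For compound 4 the estimate in this assay is 80 nM, with a range from 15 nM to 400 nM.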

Compound 4, half-maximal inhibitory concentration: 36 nM
For compound 4 the middle estimate is 2.2-fold (0.35 log units) above the measured one; the range from low to high includes it.
By their numbers in this assay, from the lowest: compound 1; then compounds 2 and 4 (each within the scatter of the next); then compound 3.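

In this assay, tying the two propyl chains into azepan-1-yl gives a 14-fold lower number from compound 3 to compound 4 (1.13 log units; beyond the scatter) even though the heavy atoms leaving and entering are the same in number and kind, so at this position the number depends on more than the atoms present: their arrangement as open chains or as a ring matters too. Compound 4 cannot be told apart from the cyclohexyl(methyl)amino compound, with a 2.0-fold higher number from compound 2 to compound 4 (0.30 log units; within the scatter) and no real separation, while the isopropyl(methyl)amino compound stays clearly ahead, with an 18-fold higher number from compound 1 to compound 4 (1.26 log units; beyond the scatter) separating the two. Nothing measured here explains why the ring outperforms the open chains.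

Still open, from the compounds shown here alone, is how the number changes with ring size, for instance with a pyrrolidine or piperidine ring in place of azepan-1-yl. Also open, going by these compounds, is whether a ring holding a second hetero atom, such as morpholine, would keep the number of compound 4.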